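The compounds below may be only part of what the source reports. "The series", "measured", "known", "first", "only" and "open" are said of these compounds alone.

Compound 2, `S=C(N/N=C/c1ccc2ccccc2n1)Nc1ccc(Cl)cc1`, does not give a number in a functional assay on HeLa cells (Homo sapiens) for antiproliferative activity, read by sulforhodamine B assay, with a stated time of 72 h; on this read-out lower numbers stand for stronger inhibition and higher numbers for weaker inhibition: its value of > 100000 nM is a limit of the assay (the limit of > 100000 nM in this assay, at which 1 of the 2 values shown sits). Compound 1, `FC(F)(F)c1ccccc1NC(=S)N/N=C/c1ccc2ccccc2n1`, gives 18800 nM in this assay. Compound 3, `Cc1ccccc1NC(=S)N/N=C/c1ccc2ccccc2n1`, carries 2-methylphenyl in place of 4-chlorophenyl on an amide-type nitrogen. Among the measured compounds shown here, no step between two measured compounds is available for this change, so the expectation rests on compound 1 and its value 18800 nM alone. The expected step from compound 2 to compound 3 is an at least 3.3-fold lower number from compound 2 to compound 3 (0.52 log units; beyond the scatter), toward lower numbers. Compound 3 is therefore estimated at 30000 nM, between 8000 nM and 100000 nM.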

Compound 3, half-maximal inhibitory concentration: > 100000 nM
Compound 3 gave a limit, no number; the forecaster's own chance of this, stated with the estimate: 35%; middle value at least 3.3-fold (0.52 log units) away from the limit.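

Methyl in place of trifluoromethyl on an aromatic carbon brings an at least 5.3-fold higher number from compound 1 to compound 3 (0.72 log units; beyond the scatter) in this assay, the first readable step in this series, and it shows that the measurable activity of compound 1 does not survive this change. The step between compound 2 and compound 3 cannot be read, because both values are limits: the limit of > 100000 nM in this assay, at which 2 of the 3 values shown sit.

Going by these compounds, whether a methoxy or a nitrile on that aromatic carbon would also give a number remains open. So does what 2-chlorophenyl on the amide-type nitrogen would give.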